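A few compounds are considered here, and "the series" means these few. Any claim that something is new, unique, unknown or untested is made for them only; others in the source may bear on it.

In a functional assay on HepG2 cells for inhibition of squalene monooxygenase (Homo sapiens) (on this read-out lower numbers stand for stronger inhibition and higher numbers for weaker inhibition), compound 3, `CCN(C/C=C/C#CC(C)(C)C)Cc1cccc(OCCN(C)S(=O)(=O)c2ccc(F)cc2)c1`, gives 255 nM. Among the three measured numbers this is the second highest; compound 2, `CCN(C/C=C/C#CC(C)(C)C)Cc1cccc(OCCN(C)S(=O)(=O)c2ccsc2)c1`, gives 250 nM in this assay, and compound 1, `CCN(C/C=C/C#CC(C)(C)C)Cc1cccc(OCCNS(=O)(=O)c2cccs2)c1`, gives 450 nM, and each of those lies within the scatter of compound 3.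

Compound 4, `CCN(C/C=C/C#CC(C)(C)C)Cc1cccc(OCCN(C)S(=O)(=O)c2ccc(C#N)cc2)c1`, differs from compound 3 in one place: cyano in place of fluoro on an aromatic carbon. The measured steps that bear on this are both small. The change from a thiophen-3-yl to a 4-fluorophenyl group on the sulfonyl sulfur gave a 1.0-fold higher number from compound 2 to compound 3 (0.01 log units; within the scatter), and the earlier reshaping of the sulfonamide portion gave a 1.8-fold lower number from compound 1 to compound 2 (0.26 log units; within the scatter). Neither variation of the group on the sulfonyl sulfur moved this assay beyond its scatter, so another exchange at the same position is expected to behave alike: no step beyond the scatter, in either direction, in this assay.

Compound 4 is therefore expected to give about 260 nM in this assay, with a range from 120 nM to 550 nM, which means an expected step of a 1.0-fold higher number from compound 3 to compound 4 (0.01 log units; within the scatter) from compound 3.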

Compound 4, half-maximal inhibitory concentration: 200 nM
Beside the measured number, compound 4's estimate is 1.3-fold (0.11 log units) above it; low and high end bracket the measured number.
By their numbers in this assay, from the lowest: compounds 4, 2, 3 and 1 (each within the scatter of the next, the first and the last beyond it).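

In this assay, cyano in place of fluoro on an aromatic carbon, para to a large group, gives a 1.3-fold lower number from compound 3 to compound 4 (0.11 log units; within the scatter) and so stays within the scatter, while 4-cyanophenyl in place of thiophen-3-yl on the sulfonyl sulfur gives a 1.3-fold lower number from compound 2 to compound 4 (0.10 log units; within the scatter) and also stays within it. The earlier compounds had shown only two groups on this sulfonyl sulfur; the third now brings a triple bond and a hydrogen-bond acceptor into the substituent, and the read-out still does not leave the scatter for compound 2, compound 3 and compound 4, which share the methyl on the sulfonamide nitrogen. Nothing at hand accounts for this flat response.

Among these compounds, whether an amine or a carboxylic acid in place of the cyano would also stay within the scatter remains open, since all the groups at this place so far leave the read-out flat and none marks where that flatness ends. Also open, going by these compounds, is whether the 4-cyanophenyl group would behave alike with a hydrogen in place of that methyl, or with any change to the rest of the shared core.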